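This account rests on a few compounds, and the source may have more. Where it says the series, first, only, none or still open, it means among the compounds named here.

Measured compounds in a functional assay on DLD-1 cells (Homo sapiens) for antiproliferative activity, read by CellTiter-Glo, with a stated time of 72 h; a higher number here means a weaker inhibitor, a lower number a stronger inhibitor:

compound 1, `Cc1cc(C)c(S(=O)(=O)N2CCC(N3CCC(C)CC3)CC2)c(C)c1`, gives 0.03 nM
compound 2, `Cc1cc(C)c(S(=O)(=O)N2CCC(N3CCC(CCO)CC3)CC2)c(C)c1`, gives 19 nM
compound 3, `Cc1cc(C)c(S(=O)(=O)N2CCC(N3CCC(CCC#N)CC3)CC2)c(C)c1`, gives only a limit of the assay, > 5000 nM

Compound 3 therefore stands at the limit of > 5000 nM in this assay, at which 1 of the 3 values shown sits, and carries no number; it is the weakest of the three shown, with both steps toward it beyond the scatter.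

Compound 4, `Cc1cc(C)c(S(=O)(=O)N2CCC(N3CCC(Cc4ccc(F)cc4)CC3)CC2)c(C)c1`, differs from compound 3 by 4-fluorophenyl in place of cyanomethyl on a saturated chain carbon bound to a saturated ring carbon. Going by the values given here, two measured steps touch this chain carbon: a 630-fold higher number from compound 1 to compound 2 (2.80 log units; beyond the scatter) and an at least 160000-fold higher number from compound 1 to compound 3 (5.22 log units; beyond the scatter), each a large loss when anything beyond hydrogen is placed there, and an at least 260-fold higher number from compound 2 to compound 3 (2.42 log units; beyond the scatter) adds a further large loss for cyano over hydroxy. No measured step covers an aromatic ring at this position, and the starting point is a limit, so the size of the step to compound 4 cannot be read from any shown number. The expectation is that compound 4 remains a weak inhibitor in this assay, with a wide range either side.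

Compound 4 is estimated at 2000 nM, between 200 nM and 20000 nM. Relative to the limit of compound 3 this is an expected step of an at least 2.5-fold lower number from compound 3 to compound 4 (0.39 log units; beyond the scatter).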

Compound 4, half-maximal inhibitory concentration: 18 nM
Compound 4: middle estimate off by 110-fold (2.05 log units), on the high side; the whole stated range lies above it.
By their numbers in this assay, from the lowest: compound 1; then compounds 4 and 2 (each within the scatter of the next). At a limit, above all of these: compound 3.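

Compound 3 remains a limit of the assay and not a number, so the size of its step carries only a bound: the limit of > 5000 nM in this assay, at which 1 of the 4 values shown sits.

In this assay, placing 4-fluorophenyl instead of cyanomethyl on this saturated chain carbon gives an at least 270-fold lower number from compound 3 to compound 4 (2.44 log units; beyond the scatter), and placing it instead of hydroxymethyl gives a 1.1-fold lower number from compound 2 to compound 4 (0.02 log units; within the scatter), so the severe loss seen with cyanomethyl does not extend to every group at this position, and a group carrying an aromatic ring sits level with one that has no ring. The hydrogen-to-4-fluorophenyl change still gives a 600-fold higher number from compound 1 to compound 4 (2.78 log units; beyond the scatter), so among the groups shown here, none comes close to restoring the number of compound 1, and any substituent shown on this chain carbon carries a large loss.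

The compounds shown leave open whether the aromatic ring or the fluorine accounts for the recovery from cyanomethyl, which an unsubstituted phenyl at the same place would begin to separate. Also open, on these data alone, is how a primary amine, a carboxylic acid or a longer alkyl chain on this carbon would read in this assay, and whether any group fills the gap between compound 1 and the rest.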